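The source may hold more compounds than are shown below. What is called first, only, known or untested is meant among the compounds shown, and "the series" means these compounds.

Working notes. In a functional assay for inhibition, read by spectrophotometry, with a stated time of 20 min, tested at 5 mg/mL (on this read-out lower numbers stand for a weaker effect and higher numbers for a stronger effect at the one concentration tested), compound 2 `CC(=O)c1ccc(NC(=O)CN(C(=O)c2ccccc2)S(=O)(=O)c2ccc([N+](=O)[O-])cc2)cc1` gives 20.7%. For the measured compounds named here, the only other number in this assay comes from compound 1 `CC(=O)c1ccc(NC(=O)CN(C(=O)c2ccccc2)S(=O)(=O)c2ccc(C)cc2)cc1` at 18.7%, and the step of a number 2 percentage points higher from compound 1 to compound 2 (within the scatter) lies within the scatter, so the two values cannot be ordered. Compound 3 `CCC(C)C(C(=O)Nc1ccc(C(C)=O)cc1)N(C(=O)c1ccccc1)S(=O)(=O)c1ccc([N+](=O)[O-])cc1` has not been measured in this assay. It differs from compound 2 by sec-butyl in place of hydrogen on a saturated chain carbon bound to an amide-type nitrogen and a carbonyl carbon. Going by the values given here, the one measured step concerns a nitro in place of methyl on an aromatic carbon and does not touch the saturated chain carbon where the new group enters, so no measured step bears directly on the present change, and the one that exists is itself within the scatter. With nothing in the series pointing either way, the step of a number 0.3 percentage points higher from compound 2 to compound 3 (within the scatter) is expected to stay within the scatter. For compound 3 the estimate in this assay is 21%, with a range from 11% to 31%.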

Compound 3, a percentage reported as inhibition, at one concentration (the size of the read-out at that concentration, not a potency): 53.2%
Beside the measured number, compound 3's estimate is 32.2 percentage points below it, and the stated range ends below it.
By their numbers in this assay, from the lowest: compounds 1 and 2 (each within the scatter of the next); then compound 3.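

In this assay, sec-butyl in place of hydrogen on the saturated chain carbon bound to an amide-type nitrogen and a carbonyl carbon gives a number 32.5 percentage points higher from compound 2 to compound 3 (beyond the scatter). For the compounds shown here, this is the first step that lies beyond the scatter, which shows that the read-out at the one concentration tested responds to a change at this saturated chain carbon, whereas the one earlier step, on an aromatic carbon, did not separate its two compounds. Nothing available explains why the sec-butyl group has this effect.

The compounds shown leave open whether the step depends on the particular sec-butyl group, since a shorter chain such as ethyl, a longer chain, an amine or a carboxylic acid on the same carbon would each test this. They also leave open whether sec-butyl gives a similar step when methyl stands in place of nitro on the aromatic carbon.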